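Swapping Chloro for Bromo on the Thioether Ring

The source may hold more compounds than are shown below. What is called first, only, known or untested is meant among the compounds shown, and "the series" means these compounds.

Within the data shown here, compound 2 `CC(O)(CSc1ccc(Cl)cc1)c1nc(-c2ccc(F)c(Cl)c2)no1` gives 500 nM in a functional assay on DU-145 cells (Homo sapiens) for cytotoxicity, read by MTT assay (a higher number here means a weaker inhibitor, a lower number a stronger inhibitor), the lowest of the three numbers measured so far. Compound 1 `CC(O)(CSc1ccccc1)c1nc(-c2ccc(F)c(Cl)c2)no1` gives 5500 nM, and compound 3 `CC(O)(CSc1ccc(Cl)cc1)c1nc(-c2ccc(Cl)cc2)no1` gives 14500 nM. Both measured steps are large: an 11-fold lower number from compound 1 to compound 2 (1.04 log units; beyond the scatter) and a 29-fold higher number from compound 2 to compound 3 (1.46 log units; beyond the scatter). Compound 4 `CC(O)(CSc1ccc(Br)cc1)c1nc(-c2ccc(F)c(Cl)c2)no1` differs from compound 2 by bromo in place of chloro on an aromatic carbon. Neither measured step covers this exchange directly: one introduces the chloro that compound 4 now replaces, the other alters a different ring. Since a halogen remains in the same place, the expectation is that compound 4 stays near compound 2, with no step beyond the scatter. Compound 4 is therefore estimated at 500 nM, between 200 nM and 1500 nM, a step of no change at the digits printed from compound 2 to compound 4 (within the scatter).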

Compound 4, half-maximal inhibitory concentration: 8800 nM
Compound 4: middle estimate off by 18-fold (1.25 log units), on the low side; the measured number lies above the stated range.
By their numbers in this assay, from the lowest: compound 2; then compounds 1, 4 and 3 (each within the scatter of the next, the first and the last beyond it).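

The step (an 18-fold higher number from compound 2 to compound 4 (1.25 log units; beyond the scatter)) shows that in this assay this position does not treat its two halogens alike: bromo does not keep what chloro gained. Bromo and hydrogen stand within the scatter of each other (a 1.6-fold higher number from compound 1 to compound 4 (0.20 log units; within the scatter)), so among these three groups, only chloro gives the lower number. Nothing measured here accounts for the gap between the two halogens.

As far as these compounds go, whether a fluoro, methyl or methoxy group here would track chloro or bromo stays open. So does whether bromo would have the same effect alongside the 4-chlorophenyl of compound 3.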